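Cytotoxicity notes: from compound 3 to compound 4

The source may hold more compounds than are shown below. What is called first, only, known or untested is meant among the compounds shown, and "the series" means these compounds.

Measured in a toxicity assay on MDCK cells (Canis lupus familiaris) for cytotoxicity, read by crystal violet staining, with a stated time of 48 h; a higher number here means that more compound is tolerated, a lower number that less compound is tolerated:
- compound 1 `CC(c1ccc(OC(F)(F)F)c(Cl)c1)N(Cc1ccc(C(C)(C)C)cc1)Cc1cc2cc(C3CC3)ccc2[nH]c1=O`: > 10000 nM, a limit of the assay
- compound 2 `CC(c1ccc(N(C)C)c(Cl)c1)N(Cc1ccc(C(C)(C)C)cc1)Cc1cc2cc(Br)ccc2[nH]c1=O`: 6100 nM
- compound 3 `COc1ccc(C(C)N(Cc2ccc(C(C)(C)C)cc2)Cc2cc3cc(Br)ccc3[nH]c2=O)cc1Cl`: > 10000 nM, a limit of the assay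

Compound 3 stands at the assay limit, as does compound 1 (the limit of > 10000 nM in this assay, at which 2 of the 3 values shown sit). Among the compounds with values here, the one step that reaches compound 3 is an at least 1.6-fold higher number from compound 2 to compound 3 (0.21 log units; that floor lies within the scatter), which changes a different group. Compound 4 `CC(c1ccc(OC(F)(F)F)c(Cl)c1)N(Cc1ccc(C(C)(C)C)cc1)Cc1cc2cc(Br)ccc2[nH]c1=O` differs from compound 3 by trifluoromethyl in place of methyl on an oxygen on an aromatic ring. Within the data shown here, no measured step covers this change; compound 1, which carries the trifluoromethoxy group, and compound 3 both sit at the limit. The step from compound 3 to compound 4 is therefore expected to stay within the scatter, a step that the limit leaves unreadable from compound 3 to compound 4. Compound 4 is estimated at 12000 nM, in the range 5000 nM to 30000 nM, most likely again reported as a limit.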

Compound 4, half-maximal cytotoxic concentration: > 10000 nM
Compound 4 ended at the assay's limit; the forecaster's own chance of this, stated with the estimate: 65%; the middle value does not contradict the limit.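

With compound 4, the trifluoromethoxy group now sits on the bromo compound, and in this assay this compound also reaches the limit: the limit of > 10000 nM in this assay, at which 3 of the 4 values shown sit.

Within the data shown here, the one readable step is an at least 1.6-fold higher number from compound 2 to compound 4 (0.21 log units; that floor lies within the scatter), so the swap from dimethylamino to trifluoromethoxy shows nothing beyond the scatter. The steps reaching compound 4 from compound 3 and from compound 1 cannot be read, as both ends are limits.

From the compounds shown here alone, the true values of compound 1, compound 3 and compound 4 remain open. So does whether a carboxylic acid or a primary amine in place of the trifluoromethoxy group would give a value inside the assay's range.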